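The compounds below may be only part of what the source reports. "The series", "measured", "known", "first", "only" and "open" are said of these compounds alone.

Of the compounds shown here, three that share one core have been tested in an ADME assay on MT4 cells (Homo sapiens) for cytotoxicity, read by MTT assay, with a stated time of 4 days; a lower number here means that less compound is tolerated, a higher number that more compound is tolerated. Compound 1 `CNC(=O)Nc1c(C)c(C(OC(C)(C)C)C(=O)O)c(-c2ccc(C)c(C)c2)c(C)c1-c1ccc(C)c(C)c1` gives 20000 nM in this assay. Compound 2 `Cc1ccc(-c2c(C)c(-c3ccc(C)c(C)c3)c(C(OC(C)(C)C)C(=O)O)c(C)c2NC(=O)c2ccccc2)cc1C` gives 9100 nM in this assay, and compound 3 `Cc1ccc(-c2c(C)c(-c3ccc(C)c(C)c3)c(C(OC(C)(C)C)C(=O)O)c(C)c2NS(=O)(=O)C2CC2)cc1C` gives 11000 nM in this assay. Compound 3 thus stands second highest of the three, yet both of its neighbours lie within the usual scatter: a 1.2-fold higher number from compound 2 to compound 3 (0.08 log units; within the scatter), and a 1.8-fold lower number from compound 1 to compound 3 (0.26 log units; within the scatter).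

The new compound 4 `CCNC(=O)Nc1c(C)c(C(OC(C)(C)C)C(=O)O)c(-c2ccc(C)c(C)c2)c(C)c1-c1ccc(C)c(C)c1` differs from compound 3 in one place: ethylcarbamoyl in place of cyclopropylsulfonyl on a nitrogen on an aromatic ring. Going by the values given here, two measured steps bear on this change. The step from compound 1 to compound 3 runs almost in reverse of the present one, with compound 1 carrying a methylcarbamoyl group where compound 4 carries an ethylcarbamoyl group on the same nitrogen, and that step stayed within the scatter. The step of a 1.2-fold higher number from compound 2 to compound 3 (0.08 log units; within the scatter) likewise shows that swapping one group on that nitrogen for another moved the number little. Compound 4 is therefore expected to land near compound 1. In this assay the expected step is a 1.5-fold higher number from compound 3 to compound 4 (0.16 log units; within the scatter), which is within the scatter. Compound 4 is estimated at 16000 nM in this assay, with a range from 8000 nM to 32000 nM.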

Compound 4, half-maximal cytotoxic concentration: 15000 nM
Compound 4: middle estimate off by 1.1-fold (0.03 log units), on the high side; low and high end bracket the measured number.
By their numbers in this assay, from the lowest: compounds 2, 3, 4 and 1 (each within the scatter of the next, the first and the last beyond it).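

In this assay, the ethylcarbamoyl group on a nitrogen on an aromatic ring cannot be told apart from the cyclopropylsulfonyl group (a 1.4-fold higher number from compound 3 to compound 4 (0.13 log units; within the scatter)) or from the benzoyl group (a 1.6-fold higher number from compound 2 to compound 4 (0.22 log units; within the scatter)), even though the group that enters has no ring and swaps a hydrogen-bond acceptor for a hydrogen-bond donor. Extending the methylcarbamoyl group to ethylcarbamoyl, with methyl in place of hydrogen on the chain, also leaves the reading within the scatter (a 1.3-fold lower number from compound 1 to compound 4 (0.12 log units; within the scatter)), so compound 4 lies within the scatter of both compound 1 and compound 2, although those two are themselves just beyond it. Taken together, the four groups tried at this position so far give closely spaced numbers, and nothing measured here explains why the values fall as they do.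

Still open, as far as these compounds go, is whether a longer chain on the carbamoyl group, such as butyl, or a bare amine or a carboxylic acid at this nitrogen, would move the number clearly beyond the scatter. The compounds shown also leave open whether these groups stay this close in any other kind of test.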